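Chloro to methyl on the aryl piperazine of compound 1

The source may hold more compounds than are shown below. What is called first, only, known or untested is meant among the compounds shown, and "the series" means these compounds.

Measured compounds:
compound 1 `CCCc1nc(-c2ccccc2)c(CNCCN2CCN(c3ccccc3Cl)CC2)o1` gives 60.1%
compound 2 `CCCc1nc(-c2ccccc2)c(CNCCCN2CCN(c3ccc(OC)cc3)CC2)o1` gives 42.1%

For the measured compounds named here, in an assay on HEK293 cells for inhibition of Voltage-dependent T-type calcium channel subunit alpha-1G (Homo sapiens), read by fluorescence, tested at 10 uM (on this read-out higher numbers stand for more inhibition at the one concentration tested (going by the name of the read-out) and lower numbers for less inhibition), compound 1 stands highest of the two numbers known; the nearest, compound 2, lies lower by a margin beyond the scatter. The unmeasured compound 3 `CCCc1nc(-c2ccccc2)c(CNCCN2CCN(c3ccccc3C)CC2)o1` differs from compound 1 as follows: methyl in place of chloro on an aromatic carbon. Going by the values given here, no measured pair shows this change, so its size is unknown. The step from compound 1 to compound 3 is expected to be small, within or near the scatter, perhaps slightly downward, at a number 5.1 percentage points lower from compound 1 to compound 3 (within the scatter). Compound 3 is thus expected to give 55%, between 35% and 75%.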

Compound 3, a percentage reported as inhibition, at one concentration (the size of the read-out at that concentration, not a potency): 51.3%
Estimate against measurement, compound 3: 3.7 percentage points above, and the stated range covers the measured number.
By their numbers in this assay, from the lowest: compounds 2, 3 and 1 (each within the scatter of the next, the first and the last beyond it).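

In this assay the change from 2-chlorophenyl to 2-methylphenyl gives a number 8.8 percentage points lower from compound 1 to compound 3 (within the scatter) and so stays inside the usual scatter. For the compounds shown here, on this aromatic carbon, ortho to a large group, methyl can thus replace chloro with no step distinguishable from scatter, something the earlier compounds could not show. No evidence on hand bears on this result.

Still open, on these data alone, is whether a nitrile, an amine or a carboxylic acid at this place would read the same. As far as these compounds go, it is also open whether a longer chain would leave this change just as small.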